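Swapping Fluorines for a Hydroxy and Methyl Group

The compounds below may be only part of what the source reports. "The series", "measured", "known", "first", "only" and "open" are said of these compounds alone.

- In a functional assay on G-361 cells (Homo sapiens) for antiproliferative activity, with a stated time of 72 h (on this read-out higher numbers stand for weaker inhibition and lower numbers for stronger inhibition), compound 1 `OC[C@H]1O[C@@H](n2cnc3c(NCc4ccccc4Cl)ncnc32)[C@H](O)[C@@H]1O` gives "not determined" (no result reported) (no result reported)
- In this assay compound 2 `OC[C@H]1O[C@@H](n2cnc3c(NCc4ccc(F)c(F)c4F)ncnc32)[C@H](O)[C@@H]1O` gives > 166000 nM as a limit, not a number

Compound 2 therefore stands at a limit of the assay, and compound 1 offers no number for comparison. Going by the values given here, compound 3 `Cc1cccc(CNc2ncnc3c2ncn3[C@@H]2O[C@H](CO)[C@@H](O)[C@H]2O)c1O` carries 2-hydroxy-3-methylphenyl in place of 2,3,4-trifluorophenyl on a saturated chain carbon bound to a nitrogen on an aromatic ring (the only change). Among the compounds with values here, no measured step guides this estimate. In this assay a step towards stronger inhibition, beyond the usual scatter, is expected, estimated as an at least 11-fold lower number from compound 2 to compound 3 (1.04 log units; beyond the scatter) with wide uncertainty. Compound 3 is expected at 15000 nM (estimated range 1000 nM to 120000 nM) in this measurement.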

Compound 3, half-maximal inhibitory concentration: > 166000 nM
Compound 3 gave a limit, no number; the forecaster's own chance of this, stated with the estimate: 35%; middle value at least 11-fold (1.04 log units) from the limit.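

Compound 2 and compound 3 both end at a limit rather than a number, so no step between them can be read: the limit of > 166000 nM in this assay, at which 2 of the 3 values shown sit.

On these data alone, whether 2,3,4-trifluorophenyl and 2-hydroxy-3-methylphenyl differ at all in this assay stays open.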